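Straightening the alkoxy chain on the shared core

A few compounds are considered here, and "the series" means these few. Any claim that something is new, unique, unknown or untested is made for them only; others in the source may bear on it.

Three compounds of the series have numbers in a functional assay on HepG2 cells (Homo sapiens) for cytotoxicity, read by MTT assay, with a stated time of 48 h; on this read-out higher numbers stand for weaker inhibition and lower numbers for stronger inhibition. Compound 1 `C=CCOc1ccc2c(NCCCN(C)C)ccnc2c1` gives 3990 nM, compound 3 `CCOc1ccc2c(NCCN(C)C)ccnc2c1` gives 5680 nM, and compound 2 `CC(C)COc1ccc2c(Cl)ccnc2c1` gives 2250 nM. Compound 2 has the lowest of the three numbers; the gap to compound 1 lies within the usual scatter, so those two cannot be ordered, while the gap to compound 3 lies beyond it, so compound 2 inhibits more strongly than compound 3.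

Compound 4 `CCCCOc1ccc2c(Cl)ccnc2c1` has not yet been measured in this assay. Compared with compound 2 the change is propyl in place of isopropyl on a saturated chain carbon bound to an oxygen on an aromatic ring; the two have the same atoms, joined differently. Going by the values given here, no step between measured compounds bears on such a change, so the expectation rests on compound 2 alone. A step no larger than the scatter is expected, in either direction, so the expected step of a 1.1-fold lower number from compound 2 to compound 4 (0.03 log units; within the scatter) is set close to nothing. Compound 4 is expected to give 2100 nM, within a range from 900 nM to 4800 nM.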

Compound 4, half-maximal inhibitory concentration: 2640 nM
Beside the measured number, compound 4's estimate is 1.3-fold (0.10 log units) below it, within the range that was stated.
By their numbers in this assay, from the lowest: compounds 2, 4, 1 and 3 (each within the scatter of the next, the first and the last beyond it).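

Isobutoxy to butoxy on the shared core gives a 1.2-fold higher number from compound 2 to compound 4 (0.07 log units; within the scatter) in this assay, the first step in the series that isolates this change. The rearrangement of the chain, with its heavy-atom count unchanged, therefore has no readable effect on the number in this pair, and compounds 2 and 4 cannot be ordered. No measurement available here offers an explanation for this result.

Going by these compounds, it remains open whether a larger change on the oxygen, such as a benzyl group or a longer chain such as hexyl, would move the number beyond the scatter. Also open, on these data alone, is whether the same isobutoxy to butoxy change would read alike on a core carrying the amine chain of compound 1 rather than the chlorine of compounds 2 and 4.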